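Adding tert-butyl to the lowest-clearance compound

The source may hold more compounds than are shown below. What is called first, only, known or untested is meant among the compounds shown, and "the series" means these compounds.

Within the data shown here, in an ADME assay (liver, Mus musculus) for metabolic stability, using microsomes (on this read-out higher numbers stand for fast clearance and lower numbers for slow clearance), compound 3 `CN(Cc1ccccc1)C(=O)n1cnc(S(=O)(=O)[C@@H]2C[C@H]3CC[C@@H]2C3)n1` gives 4 mL.min-1.g-1, the lowest number so far. Compound 1 `CC(C)N(C(=O)n1cnc(S[C@@H]2C[C@H]3CC[C@@H]2C3)n1)C(C)C` gives a clearly higher 22 mL.min-1.g-1. Compound 2 `O=C(N1CCCC1)n1cnc(S[C@@H]2C[C@H]3CC[C@@H]2C3)n1` reads > 30 mL.min-1.g-1, which is a limit of the assay and not a number. Compound 4 `CN(Cc1ccc(C(C)(C)C)cc1)C(=O)n1cnc(S(=O)(=O)[C@@H]2C[C@H]3CC[C@@H]2C3)n1` has tert-butyl in place of hydrogen on an aromatic carbon, para to a large group (tert-butyl in place of hydrogen on an aromatic carbon). Among the measured compounds shown here, the only measured step, an at least 1.3-fold higher number from compound 1 to compound 2 (0.13 log units; that floor lies within the scatter), changes a different part of the molecule, so it is a weak guide. For the measured compounds named here, no measured step touches the aromatic ring. With compound 3 at 4 mL.min-1.g-1, a rise is the likelier direction, but this is a judgement and not a measured trend. The expected step is a 3.0-fold higher number from compound 3 to compound 4 (0.48 log units; beyond the scatter). For compound 4 the estimated value is 12 mL.min-1.g-1, with an expected range from 5 mL.min-1.g-1 to 30 mL.min-1.g-1.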

Compound 4, intrinsic clearance in microsomes: 7.8 mL.min-1.g-1
Estimate against measurement, compound 4: 1.5-fold (0.19 log units) above; measured number inside the range.
By their numbers in this assay, from the lowest: compounds 3 and 4 (each within the scatter of the next); then compound 1. At a limit, above all of these: compound 2.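

Among these compounds, this is the first measured step on the aromatic ring: in this assay the change from phenyl to 4-(tert-butyl)phenyl gives a 2.0-fold higher number from compound 3 to compound 4 (0.29 log units; within the scatter) for this pair. So a tert-butyl can sit on this aromatic carbon without a step beyond the usual scatter. Nothing measured here speaks to the reason for this result. From the compounds shown here alone, it remains open whether a methoxy group, an amine or a carboxylic acid on the same carbon would read alike. A single pair also cannot tell whether tert-butyl would behave the same way on a different amide.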